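The source may report more compounds than this note shows. Statements on the series, on what has been measured and on what is new or still open speak of the compounds shown alone.

Measured so far:
compound 1, `O=C(Nc1ccccc1)C(Cl)Cl`, 130000 nM
compound 2, `O=C(Nc1cccc(OC(=O)C(Cl)Cl)c1)C(Cl)Cl`, "not determined" (no result reported)

For the measured compounds named here, in a functional assay on A549 cells (Homo sapiens) for antiproliferative activity, read by MTT assay, with a stated time of 72 h (on this read-out lower numbers stand for stronger inhibition and higher numbers for weaker inhibition), compound 1 gives 130000 nM, the only number in the set so far. Going by the values given here, for compound 2 this assay gives "not determined" (no result reported), so no second number exists, and no step between measured compounds can be drawn. Compound 3, `O=C(Nc1ccc(SC(F)(F)F)cc1)C(Cl)Cl`, is the next candidate; it differs from compound 1 by (trifluoromethyl)sulfanyl in place of hydrogen on an aromatic carbon. Among the compounds with values here, with only one measured number, no step of the same kind is available to set a size. The expectation for the step from compound 1 to compound 3 in this assay is a modest move toward stronger inhibition, a 3.3-fold lower number from compound 1 to compound 3 (0.51 log units; beyond the scatter), with wide uncertainty on either side. Compound 3 is therefore expected at about 40000 nM, with a likely range from 10000 nM to 150000 nM.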

Compound 3, half-maximal inhibitory concentration: 10600 nM
Compound 3: the middle estimate sits 3.8-fold (0.58 log units) above what was measured; the measured number falls inside the stated range.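

In this assay, for the compounds shown here, the change of hydrogen to (trifluoromethyl)sulfanyl on an aromatic carbon, para to a group of 6 heavy atoms, gives a 12-fold lower number from compound 1 to compound 3 (1.09 log units; beyond the scatter) and is the first step the series can be read by. This position therefore accepts a group of 5 heavy atoms with a large move toward stronger inhibition, which compound 1 alone could not show. Nothing measured on the compounds bears on why this step is so large.

On these data alone, it remains open whether the sulfur is needed, or whether a trifluoromethyl, a methyl or a chlorine at the same place would give a step of like size. As far as these compounds go, it is equally open how an amine or a carboxylic acid would behave there, and whether (trifluoromethyl)sulfanyl would give the same step on another aromatic carbon of the ring.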